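Swapping the Ring on the Thiocarbonyl Carbon

This account rests on a few compounds, and the source may have more. Where it says the series, first, only, none or still open, it means among the compounds named here.

Of the compounds shown here, three sharing one core have been measured in a functional assay on A-431 cells (Homo sapiens) for cytotoxicity, read by MTT assay, with a stated time of 72 h, tested at 100 uM; a lower number here means less inhibition of growth, a higher number more inhibition of growth at the concentration tested. Compound 1 `Cc1ccnc(/C(N)=N/NC(=S)N2CCSCC2)c1` gives 79.6%. Compound 2 `N/C(=N\NC(=S)N1CCCC1)c1ccccn1` gives 83.8%. Compound 3 `Cc1ccnc(/C(N)=N/NC(=S)N2CCCCC2)c1` gives 77.6%, which is the lowest of the three numbers, though its gap to compound 1 and its gap to compound 2 both lie within the scatter, so no order among them can be read from this.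

Compound 4 `Cc1ccnc(/C(N)=N/NC(=S)N2CCCC2)c1` is not yet measured. It differs from compound 3 in one place: pyrrolidin-1-yl in place of piperidin-1-yl on a thiocarbonyl carbon. Among the measured compounds shown here, the one measured step that changes the ring on the thiocarbonyl carbon, a number 2 percentage points lower from compound 1 to compound 3 (within the scatter), was within the scatter. Compound 2 carries the pyrrolidin-1-yl ring, but lacks the methyl group on the shared core, so it only shows its own value. On this basis the step from compound 3 to compound 4 in this assay is expected to be a number 2.4 percentage points higher from compound 3 to compound 4 (within the scatter), not beyond the scatter. Compound 4 is therefore estimated at 80%, within a range from 70% to 90%.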

Compound 4, percent growth inhibition at one concentration: 86.9%
Estimate against measurement, compound 4: 6.9 percentage points below, within the range that was stated.
By their numbers in this assay, from the lowest: compounds 3, 1, 2 and 4 (each within the scatter of the next).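

In this assay the ring on the thiocarbonyl carbon can shrink from six-membered to five-membered, a number 9.3 percentage points higher from compound 3 to compound 4 (within the scatter), and thiomorpholin-4-yl can give way to pyrrolidin-1-yl, a number 7.3 percentage points higher from compound 1 to compound 4 (within the scatter), so these three rings cannot be told apart at this place on the methyl-bearing core. The first direct test of the methyl group with the pyrrolidin-1-yl ring held constant, a number 3.1 percentage points higher from compound 2 to compound 4 (within the scatter), likewise shows no separation between methyl and hydrogen on that aromatic carbon. No measurement here bears on why these values fall as they do.

The compounds shown leave open whether a ring carrying an oxygen, such as morpholin-4-yl, or a second nitrogen, such as piperazin-1-yl, would also stay within the scatter on the thiocarbonyl carbon. They also leave open what an open chain, such as diethylamino, would give there.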